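Arylamino in place of dipropylamino on the shared core

This account rests on a few compounds, and the source may have more. Where it says the series, first, only, none or still open, it means among the compounds named here.

The series shares one core; compound 3 `CCCN(CCC)C1=CC(=O)c2nc3n(c2C1=O)[C@H]1OC[C@@H](O)[C@H]1OC3` carries a dipropylamino group on it. In a functional assay on HeLa cells (Homo sapiens) for inhibition, read by sulforhodamine B assay (on this read-out higher numbers stand for weaker inhibition and lower numbers for stronger inhibition), compound 3 gives only a limit, > 16000 nM. Compound 1 `CCCc1ccc(NC2=CC(=O)c3nc4n(c3C2=O)[C@H]2OC[C@@H](O)[C@H]2OC4)cc1` and compound 2 `CCOc1ccccc1NC1=CC(=O)c2nc3n(c2C1=O)[C@H]1OC[C@@H](O)[C@H]1OC3` carry arylamino groups instead. In this assay, for the measured compounds named here, compound 1 gives 4990 nM, and compound 2 gives 6040 nM; the one measured step, a 1.2-fold higher number from compound 1 to compound 2 (0.08 log units; within the scatter), shows the two arylamino groups sitting within the scatter of each other. Compound 4 `O=C1C=C(Nc2ccccc2F)C(=O)c2c1nc1n2[C@H]2OC[C@@H](O)[C@H]2OC1` brings ((2-fluorophenyl)amino in place of dipropylamino on a double-bonded ring carbon). Going by the values given here, no measured step runs from dipropylamino to an arylamino group; the only guide is that compounds 1 and 2, both arylamines, give numbers, while compound 3 reaches (the limit of > 16000 nM in this assay, at which 1 of the 3 values shown sits). Because compound 1 gives 4990 nM, compound 4 is expected near 6000 nM (range 2500 nM to 14000 nM). The expected step is an at least 2.6-fold lower number from compound 3 to compound 4 (0.42 log units; beyond the scatter).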

Compound 4, half-maximal inhibitory concentration: 5120 nM
Compound 4: middle estimate off by 1.2-fold (0.07 log units), on the high side, within the range that was stated.
By their numbers in this assay, from the lowest: compounds 1, 4 and 2 (each within the scatter of the next). At a limit, above all of these: compound 3.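

In this assay, the change to (2-fluorophenyl)amino on the double-bonded ring carbon now has a step of its own, an at least 3.1-fold lower number from compound 3 to compound 4 (0.49 log units; beyond the scatter). Compound 3 remains a limit, so this step is only a bound: the limit of > 16000 nM in this assay, at which 1 of the 4 values shown sits.
The arylamino groups stay within the scatter of one another, with a 1.2-fold lower number from compound 2 to compound 4 (0.07 log units; within the scatter) and a 1.0-fold higher number from compound 1 to compound 4 (0.01 log units; within the scatter), so 2-fluorophenyl, 2-ethoxyphenyl and 4-propylphenyl on the amine nitrogen are not told apart.

Open, as far as these compounds go, is whether the aromatic ring or the hydrogen on the amine nitrogen accounts for the step; a propylamino group at this place would separate the two. Also open, from the compounds shown here alone, is how a carboxylic acid on the aromatic ring would read.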